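The compounds below may be only part of what the source reports. "The series", "measured", "known", "first", "only" and "open" are said of these compounds alone.

Among the compounds with values here, in a functional assay on HepG2 cells (Homo sapiens) for antiproliferative activity, read by sulforhodamine B assay, with a stated time of 48 h (on this read-out higher numbers stand for weaker inhibition and lower numbers for stronger inhibition), compound 1 `COc1cccc(/C=C/C(=O)C(=Cc2ccc(F)cc2)C(=O)/C=C/c2cccc(OC)c2OC)c1OC` gives 580 nM, the highest of the three numbers measured so far. Compound 2 `COc1cc(C=C(C(=O)/C=C/c2cccc(OC)c2OC)C(=O)/C=C/c2cccc(OC)c2OC)ccc1O` gives 200 nM, and compound 3 `COc1cccc(/C=C/C(=O)C(=Cc2ccc(O)c(F)c2)C(=O)/C=C/c2cccc(OC)c2OC)c1OC` gives 220 nM. Compound 4 `COc1cc(C=C(C(=O)/C=C/c2cccc(OC)c2OC)C(=O)/C=C/c2cccc(OC)c2OC)cc(Br)c1O` has not been measured. It keeps the core of compound 1 and changes one group: 3-bromo-4-hydroxy-5-methoxyphenyl in place of 4-fluorophenyl on a double-bonded chain carbon bound to a double-bonded chain carbon. Two measured steps replace the same 4-fluorophenyl at that place. One is a 2.9-fold lower number from compound 1 to compound 2 (0.46 log units; beyond the scatter), and the other is a 2.6-fold lower number from compound 1 to compound 3 (0.42 log units; beyond the scatter). Both are modest, beyond the scatter, and run the same way. The third step, a 1.1-fold higher number from compound 2 to compound 3 (0.04 log units; within the scatter), lies within the scatter, so those two replacements cannot be told apart. Within the data shown here, the group entering compound 4 shares its hydroxy and methoxy with the one in compound 2, but no measured compound carries bromine, so what bromine adds is unknown. In this assay the expected change is a modest one toward a lower number, a 2.9-fold lower number from compound 1 to compound 4 (0.46 log units; beyond the scatter). For compound 4 the estimate is 200 nM, with an expected range of 80 nM to 500 nM.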

Compound 4, half-maximal inhibitory concentration: 240 nM
For compound 4 the middle estimate is 1.2-fold (0.08 log units) below the measured one; measured number inside the range.
By their numbers in this assay, from the lowest: compounds 2, 3 and 4 (each within the scatter of the next); then compound 1.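

In this assay, a third replacement of the 4-fluorophenyl lowers the number (a 2.4-fold lower number from compound 1 to compound 4 (0.38 log units; beyond the scatter)), so this modest step runs the same way as the two earlier ones, now with a larger group that also carries bromine. Bromo in place of hydrogen on an aromatic carbon makes no difference that can be read (a 1.2-fold higher number from compound 2 to compound 4 (0.08 log units; within the scatter)), and swapping the 3-fluoro-4-hydroxyphenyl for the new group likewise stays within the scatter (a 1.1-fold higher number from compound 3 to compound 4 (0.04 log units; within the scatter)), so the three hydroxy-bearing groups cannot be told apart here. No measurement available here explains why these groups give such similar numbers.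

On these data alone, it remains open whether a plain 4-hydroxyphenyl, with no other group on the ring, would match these three. As far as these compounds go, what an amine or a carboxylic acid in place of the hydroxy would give also remains open.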